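Compound 2 to compound 3: a new group on the carbonyl

This account rests on a few compounds, and the source may have more. Where it says the series, first, only, none or still open, it means among the compounds named here.

Compound 2 (`CCCSC(=O)COC(=O)C1=C2C(=NC1=O)c1cccc3c(SCCC)ccc2c13`) reads > 100000 nM in an ADME assay on WI-38 cells (Homo sapiens) for antiproliferative activity, read by sulforhodamine B assay, with a stated time of 72 h (a higher number here means a weaker inhibitor, a lower number a stronger inhibitor), and this is a limit of the assay, not a number. Compound 1 (`CCCSc1ccc2c3c(cccc13)C1=NC(=O)C(C(=O)OCC)=C12`) gives 9600 nM in this assay.

Compound 3 (`CCCSc1ccc2c3c(cccc13)C1=NC(=O)C(C(=O)OCC(=O)OCC(F)(F)C(F)(F)F)=C12`) differs from compound 2 at one place: 2,2,3,3,3-pentafluoropropoxy in place of propylsulfanyl on a carbonyl carbon. In words, 2,2,3,3,3-pentafluoropropoxy stands in place of propylsulfanyl on a carbonyl carbon.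

Within the data shown here, no measured step covers this exchange. The nearest is an at least 10-fold higher number from compound 1 to compound 2 (1.01 log units; beyond the scatter), a large step beyond the scatter, which put (propylsulfanyl)carbonyl in place of methyl on a saturated chain carbon. Compound 3 keeps a carbonyl at that carbon, so the expectation based on an at least 10-fold higher number from compound 1 to compound 2 (1.01 log units; beyond the scatter) is that most of the weak reading persists. Only a modest recovery towards lower numbers is expected, and a second reading at the limit would be no surprise.

The expected change is an at least 2.0-fold lower number from compound 2 to compound 3 (0.30 log units; that floor lies within the scatter), an estimate that can only be loose.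

Compound 3 is expected at about 50000 nM, with an estimated range of 15000 nM to 100000 nM.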

Compound 3, half-maximal inhibitory concentration: 58800 nM
For compound 3 the middle estimate is 1.2-fold (0.07 log units) below the measured one; the range from low to high includes it.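

With (2,2,3,3,3-pentafluoropropoxy)carbonyl on the saturated chain carbon, the cost of this extension in this assay can now be sized against a number rather than only bounded: a 6.1-fold higher number from compound 1 to compound 3 (0.79 log units; beyond the scatter). The exchange on the carbonyl carbon itself reads as an at least 1.7-fold lower number from compound 2 to compound 3 (0.23 log units; that floor lies within the scatter), and with that floor inside the scatter, this reading alone does not establish that 2,2,3,3,3-pentafluoropropoxy and propylsulfanyl differ in this assay. Compound 2 is held at a limit of the assay, not a number, and the true size of the step from it stays unknown: the limit of > 100000 nM in this assay, at which 1 of the 3 values shown sits.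

The compounds shown leave open whether the higher number of compound 3 relative to compound 1 belongs to the added carbonyl-bearing chain as such or to the group carried on that carbonyl. A free carboxylic acid or an amide formed from a simple amine at the same carbonyl carbon would test that question, as would a plain propoxy group, which would separate the oxygen exchange from the fluorine atoms.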